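Chloro for methyl on the 4-methylphenyl group

The source may report more compounds than this note shows. Statements on the series, on what has been measured and on what is new or still open speak of the compounds shown alone.

Measured so far:
compound 1 `Nc1nc(N2CCN(C(=O)COc3ccc(Cl)cc3)CC2)c2nc(CCc3ccc(F)cc3)sc2n1`: 4400 nM
compound 2 `Cc1ccc(-c2nc3c(N4CCN(C(=O)COc5ccc(Cl)cc5)CC4)nc(N)nc3s2)cc1`: 350 nM

In a functional assay on cells (Lymphocyte, Homo sapiens) (a lower number here means a stronger inhibitor, a higher number a weaker inhibitor), compound 2 stands at the lowest of the two numbers. Within the data shown here, the one recorded step is a 13-fold lower number from compound 1 to compound 2 (1.10 log units; beyond the scatter), 4-methylphenyl in place of 2-(4-fluorophenyl)ethyl. Compound 3 `Nc1nc(N2CCN(C(=O)COc3ccc(Cl)cc3)CC2)c2nc(-c3ccc(Cl)cc3)sc2n1` carries chloro in place of methyl on an aromatic carbon. Among the measured compounds shown here, no measured step bears on a chloro for methyl exchange; the only step alters the whole group, so no pull in either direction can be read from it, and nothing beyond the scatter is expected. For compound 3 the estimate is 300 nM, range 120 nM to 900 nM, meaning a 1.2-fold lower number from compound 2 to compound 3 (0.07 log units; within the scatter).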

Compound 3, half-maximal inhibitory concentration: 270 nM
Compound 3: the middle estimate sits 1.1-fold (0.05 log units) above what was measured; the range from low to high includes it.
By their numbers in this assay, from the lowest: compounds 3 and 2 (each within the scatter of the next); then compound 1.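

In this assay, chloro in place of methyl on the aromatic carbon gives a 1.3-fold lower number from compound 2 to compound 3 (0.11 log units; within the scatter), so the two groups are not told apart at this position. With a 16-fold lower number from compound 1 to compound 3 (1.21 log units; beyond the scatter), 4-chlorophenyl repeats the large step seen with 4-methylphenyl, so within these compounds that step does not depend on the methyl group. No supporting evidence bears on this result.

Going by these compounds, whether an amine, a carboxylic acid or a methoxy group on the same carbon would keep this level remains open. The same holds for a plain phenyl group with only hydrogen there.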